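The compounds below may be only part of what the source reports. "The series", "measured", "known", "first", "only" and "open" are said of these compounds alone.

Measured in a physicochemical assay for acid dissociation:
Compound 1, `CC(=O)Nc1ccc(OC(=S)Nc2ccc(Nc3ccc([N+](=O)[O-])cc3)cc2)cc1`: 9.04.
Compound 2, `CC(=O)Nc1ccc(OC(=S)Nc2ccc(Nc3ccc(C(F)(F)F)cc3)cc2)cc1`: 9.05.
Compound 3, `Oc1ccc(OC(=S)Nc2ccc(Oc3ccc(C(F)(F)F)cc3)cc2)cc1`: 9.23.

Compound 2 and compound 1 share one core and differ by nitro in place of trifluoromethyl on an aromatic carbon; the step in this assay is a number 0.01 log units lower from compound 2 to compound 1 (within the scatter). Compound 3 is built on another core; the difference between the two cores is not broken down here. Among the three numbers compound 3 stands highest, but its gaps to compound 2 and to compound 1 lie within the scatter, so no order is read from them.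

Compound 4, `O=[N+]([O-])c1ccc(Oc2ccc(NC(=S)Oc3ccc(O)cc3)cc2)cc1`, has not yet been measured in this assay. It differs from compound 3 by nitro in place of trifluoromethyl on an aromatic carbon, the same change as between compound 2 and compound 1, at the same kind of place. The step from compound 3 to compound 4 in this assay is expected to be a number 0.01 log units lower from compound 3 to compound 4 (within the scatter), beside a number 0.01 log units lower from compound 2 to compound 1 (within the scatter), resting on that single measured occurrence. Compound 4 is therefore estimated at 9.22, with a range from 8.9 to 9.55.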

Compound 4, acid dissociation constant: 9.23
Beside the measured number, compound 4's estimate is 0.01 log units below it, and the stated range covers the measured number.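

In this assay the replacement of trifluoromethyl by nitro on an aromatic carbon gives no change at the digits printed from compound 3 to compound 4 (within the scatter) on one core and a number 0.01 log units lower from compound 2 to compound 1 (within the scatter) on the other, so in both pairs the step stays inside the scatter. Within the data shown here, these two pairs show only that the change carried from one core to the other without a readable step; they do not show that this would hold on a further core or at another place. No measurement at hand bears on why the two groups read alike.

Still open, going by these compounds, is whether an amine or a carboxylic acid at that same aromatic carbon would shift the number. No pair shown isolates the differences between the two cores either.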